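Removing the amino group from compound 3

The compounds below may be only part of what the source reports. "The series", "measured", "known", "first", "only" and "open" are said of these compounds alone.

compound 1, `Cc1ccc2nc(C(=O)c3ccc(F)c(O)c3)ccc2c1`: 78%
compound 2, `Cc1cc(-c2ccc3ccc(C(=O)c4ccc(F)c(O)c4)nc3c2)ccc1O`: 80%
compound 3, `Nc1ccc2ccc(C(=O)c3ccc(F)c(O)c3)nc2c1`: 83%

All three were tested in an assay for inhibition of 17-beta-hydroxysteroid dehydrogenase type 2 (Homo sapiens), read by HPLC, with a stated time of 10 min, tested at 1 uM; on this read-out higher numbers stand for more inhibition at the one concentration tested (going by the name of the read-out) and lower numbers for less inhibition. Compound 3 holds the highest of the three numbers, but compound 2 and compound 1 lie within the usual scatter of it, so no order among them can be read. Compound 4, `O=C(c1ccc(F)c(O)c1)c1ccc2ccccc2n1`, is not yet measured; it differs from compound 3 in one place: hydrogen in place of amino on an aromatic carbon. For the measured compounds named here, the one measured step on the same kind of aromatic carbon, a number 3 percentage points higher from compound 2 to compound 3 (within the scatter), hardly moved the number, and compound 1, carrying yet another group, sits within the scatter of compound 3 as well. The step from compound 3 to compound 4 is therefore expected to stay within the scatter, a number 5 percentage points lower from compound 3 to compound 4 (within the scatter). Compound 4 is estimated at 78%, between 65% and 88%.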

Compound 4, a percentage reported as inhibition, at one concentration (the size of the read-out at that concentration, not a potency): 76%
Estimate against measurement, compound 4: 2 percentage points above; the measured number falls inside the stated range.
By their numbers in this assay, from the lowest: compounds 4, 1, 2 and 3 (each within the scatter of the next).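

In this assay hydrogen on this ring carbon gives a number 7 percentage points lower from compound 3 to compound 4 (within the scatter) and a number 4 percentage points lower from compound 2 to compound 4 (within the scatter) and also a number 2 percentage points lower from compound 1 to compound 4 (within the scatter). So amino, 4-hydroxy-3-methylphenyl and methyl are all dispensable for the inhibition seen at this one concentration, as the shared core carrying only hydrogen stays within the scatter of all three. No measurement at hand gives a reason for this. Going by these compounds, whether a carboxylic acid or a longer chain on this ring would move the number beyond the scatter stays open. A single concentration also gives no potency, so any differences in potency among these compounds remain unknown.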